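Pyrrolidinyl chain exchanged for an aromatic hydrazide arm

The source may hold more compounds than are shown below. What is called first, only, known or untested is meant among the compounds shown, and "the series" means these compounds.

Measured compounds:
compound 1 `COc1cc(OC)c2c(=O)c(OCC(=O)N/N=C/c3ccc[nH]3)c(-c3cc(OC)c(OC)c(OC)c3)oc2c1` — 3750 nM
compound 2 `COc1cc(OC)c2c(=O)c(OCCCCN3CCCC3)c(-c3cc(OC)c(OC)c(OC)c3)oc2c1` — 10400 nM
compound 3 `COc1cc(OC)c2c(=O)c(OCCCCN3CCCCC3)c(-c3cc(OC)c(OC)c(OC)c3)oc2c1` — 3030 nM

All three share one core and differ only in the group on the saturated chain carbon bound to the oxygen on the aromatic ring. In a functional assay on MDA-MB-231 cells (Homo sapiens) for cytotoxicity, read by MTT assay, with a stated time of 38 h (a higher number here means a weaker inhibitor, a lower number a stronger inhibitor), compound 2 gives the highest of the three numbers: compound 1 gives 3750 nM, a step of a 2.8-fold higher number from compound 1 to compound 2 (0.44 log units; beyond the scatter), and compound 3 gives 3030 nM, a step of a 3.4-fold lower number from compound 2 to compound 3 (0.54 log units; beyond the scatter). Compound 1 and compound 3 sit within the scatter of each other, a 1.2-fold lower number from compound 1 to compound 3 (0.09 log units; within the scatter).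

Compound 4 `COc1cc(OC)c2c(=O)c(OCC(=O)N/N=C/c3ccccn3)c(-c3cc(OC)c(OC)c(OC)c3)oc2c1` is not yet measured. Relative to compound 2 it carries a group of 11 heavy atoms (7 carbon, 3 nitrogen, 1 oxygen; one six-membered aromatic ring with 1 hetero atom) in place of a group of 8 heavy atoms (7 carbon, 1 nitrogen; one five-membered non-aromatic ring with 1 hetero atom), on a saturated chain carbon bound to an oxygen on an aromatic ring. The entering group, with one six-membered aromatic ring with 1 hetero atom, resembles the group of compound 1, which has one five-membered aromatic ring with 1 hetero atom; the step of a 2.8-fold higher number from compound 1 to compound 2 (0.44 log units; beyond the scatter) therefore bears most directly on the change, and it ran toward a higher number when the aromatic group was exchanged for the pyrrolidinyl chain. Going the other way, compound 4 is expected to return to the region of compound 1, an estimated 2.9-fold lower number from compound 2 to compound 4 (0.46 log units; beyond the scatter) in this assay, so compound 4 is expected to give 3600 nM with a range of 1500 nM to 9000 nM.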

Compound 4, half-maximal inhibitory concentration: 9890 nM
Compound 4: middle estimate off by 2.7-fold (0.44 log units), on the low side; the whole stated range lies below it.
By their numbers in this assay, from the lowest: compounds 3 and 1 (each within the scatter of the next); then compounds 4 and 2 (each within the scatter of the next).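

The arm on the saturated chain carbon bound to an oxygen on an aromatic ring is sensitive to its terminal ring: pyridin-2-yl in place of 1H-pyrrol-2-yl on a carbon with a double bond to nitrogen gives a 2.6-fold higher number from compound 1 to compound 4 (0.42 log units; beyond the scatter) in this assay, a difference that a single aromatic arm could not reveal. The hydrazide arm as such therefore does not set the number, since the pyridin-2-yl arm of compound 4 cannot be told apart from the 3-(pyrrolidin-1-yl)propyl group of compound 2, at a 1.1-fold lower number from compound 2 to compound 4 (0.02 log units; within the scatter). The piperidine side of the series also separates from this arm, at a 3.3-fold higher number from compound 3 to compound 4 (0.51 log units; beyond the scatter), so among these compounds an aromatic terminal ring does not track with the lower numbers, with compound 4 going against any such reading.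

Open, as far as these compounds go, is how a phenyl or a 1H-imidazol-2-yl in the same arm, or a morpholin-4-yl at the end of the saturated chain, would read in this assay. No measurement here accounts for the difference between the two aromatic arms.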